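The compounds below may be only part of what the source reports. "The series", "measured", "known", "first", "only" and "open" are said of these compounds alone.

Three urea compounds sharing one core have been measured in an ADME assay on Raji cells (Homo sapiens) for cytotoxicity, with a stated time of 72 h; on this read-out higher numbers stand for an effect only at larger amounts of compound and lower numbers for an effect already at smaller amounts. There, compound 1 `COC(=O)c1cccc(NC(=O)Nc2cc(C)nc3ccccc23)c1` gives 26000 nM, compound 2 `Cc1cc(NC(=O)Nc2cccc(C(F)(F)F)c2)c2ccccc2n1` gives 10000 nM and compound 3 `Cc1cc(NC(=O)Nc2cccc(OC(F)(F)F)c2)c2ccccc2n1` gives 9000 nM. Compound 3 therefore sits at the low end of these numbers, together with compound 2, and the two cannot be separated. The next compound, compound 4 `Cc1cc(NC(=O)Nc2cccc(C(C)(C)C)c2)c2ccccc2n1`, carries tert-butyl in place of trifluoromethoxy on an aromatic carbon. For the measured compounds named here, no measured compound carries tert-butyl, so the evidence is indirect. Two steps away from methoxycarbonyl were modest but beyond the scatter: trifluoromethyl gave a 2.6-fold lower number from compound 1 to compound 2 (0.41 log units; beyond the scatter), and trifluoromethoxy gave a 2.9-fold lower number from compound 1 to compound 3 (0.46 log units; beyond the scatter). The exchange most like the one at hand, trifluoromethoxy in place of trifluoromethyl, gave a 1.1-fold lower number from compound 2 to compound 3 (0.05 log units; within the scatter), which lies within the scatter. With only these three values, the expectation in this assay is for little or no movement, and a modest shift in either direction cannot be excluded. The estimated change is no change at the digits printed from compound 3 to compound 4 (within the scatter), which is not expected to go beyond the scatter. The estimate for compound 4 is 9000 nM, with an expected range from 4000 nM to 20000 nM.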

Compound 4, half-maximal effective concentration: > 25000 nM
Compound 4 was reported as a limit; the forecaster's own chance of this, stated with the estimate: 10%; middle value at least 2.7-fold (0.44 log units) from the limit.
By their numbers in this assay, from the lowest: compounds 3 and 2 (each within the scatter of the next); then compound 1.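

In this assay compound 4 gives > 25000 nM, which is a limit of the assay and not a number. Even so, it shows that this aromatic carbon, meta to a large group, is not indifferent to the group it carries: tert-butyl brings an at least 2.7-fold higher number from compound 3 to compound 4 (0.44 log units; beyond the scatter) and an at least 2.5-fold higher number from compound 2 to compound 4 (0.39 log units; beyond the scatter), whereas the earlier exchange of trifluoromethyl for trifluoromethoxy stayed within the scatter, with a 1.1-fold lower number from compound 2 to compound 3 (0.05 log units; within the scatter). The step between compound 1 and compound 4 cannot be read, and compound 4 alone stands at this limit: the limit of > 25000 nM in this assay, at which 1 of the 4 values shown sits.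

On these data alone, how far compound 4 lies beyond its limit remains open, and so does whether tert-butyl and methoxycarbonyl differ at all on this read-out. The compounds shown also leave open where a smaller alkyl group such as methyl or isopropyl, an amine or a carboxylic acid on the same aromatic carbon would fall relative to trifluoromethyl, trifluoromethoxy and tert-butyl.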